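This account rests on a few compounds, and the source may have more. Where it says the series, first, only, none or still open, it means among the compounds named here.

Of the compounds shown here, three share one core and have been tested in an ADME assay on HeLa cells (Homo sapiens) for cytotoxicity, read by sulforhodamine B assay, with a stated time of 48 h, tested at 10 uM; on this read-out higher numbers stand for more inhibition at the one concentration tested (going by the name of the read-out) and lower numbers for less inhibition. Compound 1 `COc1nc2ccc(Br)cc2cc1C(c1ccccc1)n1cc(-c2ccc(Br)cc2)nn1` gives 6.92%, compound 2 `CCOC(=O)c1cn(C(c2ccccc2)c2cc3cc(Br)ccc3nc2OC)nn1` gives -3.67%, and compound 3 `COc1nc2ccc(Br)cc2cc1C(c1ccccc1)n1cc(-c2cccc(F)c2)nn1` gives 9.04%. Compound 2 stands lowest of the three numbers: compound 1 is the nearest to it and compound 3 the furthest, and both gaps lie beyond the usual scatter of repeated measurements.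

The compound still to be measured, compound 4 `COc1nc2ccc(Br)cc2cc1C(c1ccccc1)n1cc(-c2ccc(F)cc2)nn1`, differs from compound 2 in one place.

4-fluorophenyl in place of ethoxycarbonyl on an aromatic carbon

For the measured compounds named here, two measured steps bear on this change. Going a number 12.7 percentage points higher from compound 2 to compound 3 (beyond the scatter), an aromatic ring took the place of the ethoxycarbonyl on that aromatic carbon. Going a number 10.6 percentage points lower from compound 1 to compound 2 (beyond the scatter), the reverse exchange lowered the number by a similar amount. The step of a number 2.1 percentage points higher from compound 1 to compound 3 (within the scatter) shows that the two aromatic rings so far give numbers within the scatter of each other. On these three compounds alone, exchanging ethoxycarbonyl for an aromatic ring has each time raised the read-out modestly, so a rise of similar size is expected here in this assay. The step from compound 2 to compound 4 is estimated at a number 11.7 percentage points higher from compound 2 to compound 4 (beyond the scatter). Compound 4 is therefore expected to give about 8%, with a range from -2% to 18%.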

Compound 4, a percentage reported as inhibition, at one concentration (the size of the read-out at that concentration, not a potency): 4.27%
Estimate against measurement, compound 4: 3.7 percentage points above; low and high end bracket the measured number.
By their numbers in this assay, from the lowest: compounds 2, 4, 1 and 3 (each within the scatter of the next, the first and the last beyond it).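

In this assay the exchange of ethoxycarbonyl for 4-fluorophenyl on this aromatic carbon of the five-membered ring amounts to a number 7.9 percentage points higher from compound 2 to compound 4 (within the scatter) and so shows that an aromatic ring here does not always stand clear of ethoxycarbonyl, as the 4-bromophenyl and 3-fluorophenyl groups did. The aromatic rings also stay together: 4-fluorophenyl in place of 3-fluorophenyl gives a number 4.8 percentage points lower from compound 3 to compound 4 (within the scatter) and fluoro in place of bromo gives a number 2.7 percentage points lower from compound 1 to compound 4 (within the scatter) and neither step separates the groups, so the data draw no distinction among these three rings. No measurement at hand offers a reason for any of these numbers.

Still open, from the compounds shown here alone, is whether the gap between ethoxycarbonyl and the aromatic rings holds for rings in general or only for some of them, which an unsubstituted phenyl or a methoxyphenyl at the same carbon would help to test. Going by these compounds, it is equally open whether a different kind of group there, such as an amine, a carboxylic acid or a longer alkyl chain, would move the read-out well beyond the scatter.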